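Chloro to methoxy: working notes on a small series

The source may hold more compounds than are shown below. What is called first, only, known or untested is meant among the compounds shown, and "the series" means these compounds.

compound 1 `O=C(NNc1ccnc2cc(Cl)ccc12)c1ccccc1/N=C/c1ccc(F)cc1`: 5.18
compound 2 `O=C(NNc1ccnc2cc(Cl)ccc12)c1ccccc1/N=C/c1ccc(Cl)cc1`: 5.62
compound 3 `O=C(NNc1ccnc2cc(Cl)ccc12)c1ccccc1/N=C/c1ccc(Cl)c(Cl)c1`: 6.22

In a physicochemical assay for lipophilicity, measured as octanol-water partition (a higher number here means a more lipophilic compound, a lower number a more polar compound), compound 2 stands second highest of the three, with compound 1 lower and compound 3 higher. Compound 4 `COc1ccc(/C=N/c2ccccc2C(=O)NNc2ccnc3cc(Cl)ccc23)cc1` differs from compound 2 at one place: methoxy in place of chloro on an aromatic carbon (methoxy in place of chloro on an aromatic carbon, para to a large group). Two measured single changes involve chloro entering: a number 0.44 log units higher from compound 1 to compound 2 (beyond the scatter) for chloro in place of fluoro, and a number 0.60 log units higher from compound 2 to compound 3 (beyond the scatter) for chloro in place of hydrogen on an aromatic carbon. The two together appear in a number 1.04 log units higher from compound 1 to compound 3 (beyond the scatter) for 3,4-dichlorophenyl in place of 4-fluorophenyl. Going by the values given here, no measured compound carries methoxy, so that group has no direct precedent here. On the two single steps, a modest drop in this assay is expected as chloro leaves compound 2 at 5.62 for the new compound. The estimate is a number 0.57 log units lower from compound 2 to compound 4 (beyond the scatter) as the expected step. For compound 4 the expected value is 5.05 with an estimated range from 4.7 to 5.4 in this assay.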

Compound 4, partition coefficient: 5
Beside the measured number, compound 4's estimate is 0.05 log units above it, within the range that was stated.
By their numbers in this assay, from the lowest: compounds 4 and 1 (each within the scatter of the next); then compound 2; then compound 3.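

At this place, on an aromatic carbon para to a large group, the series had shown only fluoro and chloro, and methoxy in place of chloro now gives a number 0.62 log units lower from compound 2 to compound 4 (beyond the scatter) in this assay as a change that does not involve a halogen entering. Methoxy and fluoro are not separated here, with a number 0.18 log units lower from compound 1 to compound 4 (within the scatter) as the printed step, so swapping one for the other at this place leaves the reading unresolved. The change from 3,4-dichlorophenyl to 4-methoxyphenyl gives a number 1.22 log units lower from compound 3 to compound 4 (beyond the scatter) and is now the largest step in the series.

Nothing available accounts for the size of any of these steps. On these data alone, whether an amine, a carboxylic acid or a longer chain such as ethoxy at this place would stay close to methoxy and fluoro, or move apart from them, remains open.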